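A few compounds are considered here, and "the series" means these few. Any claim that something is new, unique, unknown or untested is made for them only; others in the source may bear on it.

Compound 1 `CC1(C)C=C(n2ccccc2=O)c2cc(C(=O)c3ccccc3)ccc2O1` stands highest of the three numbers in a functional assay (trachea) with Rattus norvegicus as the target (on this read-out lower numbers stand for lower potency and higher numbers for higher potency (the scale is a negative logarithm)), where compound 1 gives 6.21. Compound 2 `CC1(C)C=C(n2ccccc2=O)c2cc(C(=O)c3ccco3)ccc2O1` gives 5.92 in this assay, and compound 3 `CC1(C)C=C(n2ccccc2=O)c2cc(C(=O)c3ccc(O)cc3)ccc2O1` gives 5.87. The step of a number 0.29 log units lower from compound 1 to compound 2 (within the scatter) lies within the scatter, while the step of a number 0.34 log units lower from compound 1 to compound 3 (beyond the scatter) is modest but beyond it, and the step of a number 0.05 log units lower from compound 2 to compound 3 (within the scatter) is again within the scatter. Compound 4 `CC1(C)C=C(n2ccccc2=O)c2cc(OS(=O)(=O)F)ccc2O1` has not yet been measured in this assay. It differs from compound 1 as follows: (fluorosulfonyl)oxy in place of benzoyl on an aromatic carbon. Both measured steps alter only the benzoyl group and leave the carbonyl in place, and both were small; the change to compound 4 removes the benzoyl altogether, so the measured steps cover it only loosely. A downward, modest step a number 0.51 log units lower from compound 1 to compound 4 (beyond the scatter) in this assay is therefore expected, with wide uncertainty. For compound 4 the estimate in this assay is 5.7, within a range from 5 to 6.4.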

Compound 4, logarithm of the reciprocal of the active concentration, log(1/C): 7.22
Estimate against measurement, compound 4: 1.52 log units below; measured number above the stated range.
By their numbers in this assay, from the lowest: compounds 3, 2 and 1 (each within the scatter of the next, the first and the last beyond it); then compound 4.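

The earlier compounds shown here changed only the ring on the carbonyl, so they could not show whether this position needs an aryl carbonyl at all. In this assay, among the compounds shown here, it does not: removing the benzoyl and placing (fluorosulfonyl)oxy, a group with no ring, on the same aromatic carbon gives a number 1.01 log units higher from compound 1 to compound 4 (beyond the scatter) and is the first large step. The rise also holds against the other two aryl ketones, with a number 1.30 log units higher from compound 2 to compound 4 (beyond the scatter) and a number 1.35 log units higher from compound 3 to compound 4 (beyond the scatter), and no measurement here bears on what lies behind it.

The compounds shown leave open whether the gain belongs to the whole (fluorosulfonyl)oxy group or to the loss of the benzoyl. They also leave open how a nitrile, a methanesulfonyl or a methoxy group would stand on this carbon.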